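Cyclohexylmethyl in Place of Cyclobutyl on the Ring Nitrogen

The source may hold more compounds than are shown below. What is called first, only, known or untested is meant among the compounds shown, and "the series" means these compounds.

Measured compounds:
- compound 1 `CC(C)c1onc(-c2c(Cl)cccc2Cl)c1COc1ccc(-c2nc3ccc(C(=O)O)cc3n2CC2CC2)cc1` gives 29.1 nM in an assay on isolated protein for agonist activity at Bile acid receptor (Homo sapiens), read by TR-FRET; a higher number here means that more compound is needed for the effect, a lower number that less compound is needed
- compound 2 `CCC(CC)n1c(-c2ccc(OCc3c(-c4c(Cl)cccc4Cl)noc3C(C)C)cc2F)nc2ccc(C(=O)O)cc21` gives 69.3 nM in this assay
- compound 3 `CC(C)c1onc(-c2c(Cl)cccc2Cl)c1COc1ccc(-c2nc3ccc(C(=O)O)cc3n2C2CCC2)cc1` gives "not determined" (no result reported) in this assay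

Compound 1 and compound 2 both carry a carboxylic acid on the shared core and a substituent on the aromatic nitrogen of the fused ring system, and their values in this assay differ by a margin that is only a little beyond the usual scatter of repeated measurements. Compound 3 carries a cyclobutyl on that nitrogen, but no number was reported for it in this assay, so it cannot be placed among the measured compounds.

Compound 4 `CC(C)c1onc(-c2c(Cl)cccc2Cl)c1COc1ccc(-c2nc3ccc(C(=O)O)cc3n2CC2CCCCC2)cc1` is the next step from compound 3. The change is cyclohexylmethyl in place of cyclobutyl on an aromatic nitrogen. For the measured compounds named here, with no result for compound 3 and no single-change step among the measured compounds, there is no measured step to lean on, and the size and direction of the change remain open.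

Given that compound 1 and compound 2 sit within a narrow band, compound 4 is expected to land near them, at roughly 45 nM with a range from 12 nM to 180 nM.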

Compound 4, half-maximal effective concentration: 19.9 nM
Compound 4: middle estimate off by 2.3-fold (0.35 log units), on the high side; low and high end bracket the measured number.
By their numbers in this assay, from the lowest: compounds 4 and 1 (each within the scatter of the next); then compound 2.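

In this assay, for the compounds shown here, the one readable step at this position is a 1.5-fold lower number from compound 1 to compound 4 (0.17 log units; within the scatter), with cyclohexyl in place of cyclopropyl on a saturated chain carbon bound to an aromatic nitrogen. Going by these compounds alone, the two values cannot be told apart, so this position accepts either ring on that carbon without a measurable difference in this assay, a finding that the earlier compounds could not provide. Compound 3 has no reported number, so the step to compound 4 cannot be read and the cyclobutyl group bound directly to the nitrogen remains unplaced, while nothing shown accounts for the result.

The compounds shown leave open whether this tolerance extends to a flat aromatic ring, as in benzyl, or to a chain ending in an amine, which would place a nitrogen in the group instead of carbon alone. They also leave open whether a longer chain between the cyclohexyl ring and the aromatic nitrogen would give a number in this assay that differs beyond the scatter.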